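Benzyl replaces pyrimidinyl on the piperazine of compound 1

The source may report more compounds than this note shows. Statements on the series, on what has been measured and on what is new or still open speak of the compounds shown alone.

Compound 1, `NS(=O)(=O)Oc1ccc2c(c1)CN(C(=O)c1cccc(N3CCN(c4ncccn4)CC3)c1)CC2`, is the weakest of the three measured compounds in an assay on HEK293 cells for inhibition of Steryl-sulfatase (Homo sapiens), tested at 1 uM (on this read-out lower numbers stand for a weaker effect and higher numbers for a stronger effect at the one concentration tested), where compound 1 gives 24.4%. Compound 3, `NS(=O)(=O)Oc1ccc2c(c1)CN(C(=O)c1ccc(N3CCCCC3)cc1)CC2`, stands nearest to it and gives 38.3% in this assay, and compound 2, `CC(C)CCN(CCC(C)C)c1ccc(C(=O)N2CCc3ccc(OS(N)(=O)=O)cc3C2)cc1`, is furthest away and gives 90.8%. Going by the values given here, the one measured step between compounds that differ in a single place is a number 52.5 percentage points lower from compound 2 to compound 3 (beyond the scatter), a piperidin-1-yl in place of diisopentylamino on an aromatic carbon.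

Compound 4, `NS(=O)(=O)Oc1ccc2c(c1)CN(C(=O)c1cccc(N3CCN(Cc4ccccc4)CC3)c1)CC2`, is the next compound. It differs from compound 1 as follows: benzyl in place of pyrimidin-2-yl on an amine nitrogen in a ring. Among the compounds with values here, the step from compound 2 to compound 3 changes a group on an aromatic carbon of the amide-bearing ring, not a substituent on the amine nitrogen in a ring, so it does not speak directly to this change; the data hold no step at that place. Within the data shown here, that step shows only that changing the group on that side of the shared core can move the read-out by a large amount. On this footing the expected step is a number 10.6 percentage points higher from compound 1 to compound 4 (beyond the scatter), a modest rise that may well fall within the scatter. Compound 4 is therefore estimated to give 35% in this assay, with a range from 15% to 60%.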

Compound 4, a percentage reported as inhibition, at one concentration (the size of the read-out at that concentration, not a potency): 23.7%
For compound 4 the middle estimate is 11.3 percentage points above the measured one, and the stated range covers the measured number.
By their numbers in this assay, from the lowest: compounds 4 and 1 (each within the scatter of the next); then compound 3; then compound 2.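

Going by these compounds alone, until this result no step had been measured on the amine nitrogen in a ring, and in this assay benzyl in place of pyrimidin-2-yl there gives a number 0.7 percentage points lower from compound 1 to compound 4 (within the scatter). Within the data shown here, at this place, then, a six-membered aromatic ring of carbon only can stand in for one with 2 hetero atoms, and the hydrogen-bond acceptors of pyrimidin-2-yl can be lost, without the read-out leaving the scatter; this is unlike the one earlier step, a number 52.5 percentage points lower from compound 2 to compound 3 (beyond the scatter), which lies at a different place on the shared core. No measured property of either group is at hand to account for this result.

Both groups compared here carry a six-membered aromatic ring, so the compounds shown leave open how the read-out would respond to a group on that nitrogen with no such ring, such as methyl or acetyl, or to the free amine with only a hydrogen there. They also leave open whether a longer chain on that nitrogen, such as isopentyl, would move the read-out beyond the scatter.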